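Removing chloro from a chromone thioamide core and its analogue

The compounds below may be only part of what the source reports. "The series", "measured", "known", "first", "only" and "open" are said of these compounds alone.

Measured compounds:
compound 1 `O=c1c(C(=S)Nc2ccccc2)coc2cc(Cl)ccc12`, 66%
compound 2 `O=c1c(C(=S)Nc2ccccc2)coc2cc(Cl)c(Cl)cc12`, 3%
compound 3 `O=c1c(C2N=C(c3ccccc3)SS2)coc2cc(Cl)ccc12`, 76%

The three measured compounds were tested in a functional assay on A549 cells (Homo sapiens) for inhibition, read by sulforhodamine B assay, with a stated time of 48 h, tested at 100 uM; a lower number here means less inhibition of growth, a higher number more inhibition of growth at the concentration tested. Compound 2 gives 3%, whereas compound 1, which differs from it by hydrogen in place of chloro on an aromatic carbon, gives 66%; the step is a number 63 percentage points higher from compound 2 to compound 1 (beyond the scatter). Compound 3 gives 76%; the difference between the core of compound 3 and the core of compound 2 is not broken down here, and the gap between compound 3 and compound 1 lies within the scatter.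

Compound 4 `O=c1c(C2N=C(c3ccccc3)SS2)coc2ccccc12` has not been measured. It differs from compound 3 by hydrogen in place of chloro on an aromatic carbon. For the measured compounds named here, this is the same kind of change as the one from compound 2 to compound 1, but not the same: in compound 2 the chloro that leaves is ortho to a chloro group, while in compound 3 no such neighbour stands on the ring. The large step of a number 63 percentage points higher from compound 2 to compound 1 (beyond the scatter) therefore carries over only loosely. Since compound 3 already gives 76%, little room for a rise remains, and compound 1 shows that a core bearing a single chloro at this place can still be strongly inhibitory, so the estimate for compound 4 in this assay is a step of a number 16 percentage points lower from compound 3 to compound 4 (beyond the scatter), which is expected to be far smaller than the measured one. Compound 4 is estimated at 60%, with an expected range from 25% to 90%.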

Compound 4, percent growth inhibition at one concentration: 42%
Beside the measured number, compound 4's estimate is 18 percentage points above it, within the range that was stated.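

In this assay, hydrogen in place of chloro on an aromatic carbon gives a step of a number 34 percentage points lower from compound 3 to compound 4 (beyond the scatter), so here the loss of chloro goes with less inhibition of growth, whereas the earlier step with the same kind of change went the other way. Within this series, the change therefore cannot be carried from one core to the other in either direction or size: the same change on two cores in this assay, a number 63 percentage points higher (beyond the scatter) from compound 2 to compound 1 and a number 34 percentage points lower (beyond the scatter) from compound 3 to compound 4, 97 percentage points apart, beyond the scatter of two such steps. For the compounds shown here, this rests on only two pairs, and the two cores differ from each other in more than one place, so the pairs do not show which difference separates the two steps, nor do they offer a rule for any further core.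

The compounds shown leave open how this assay would read if the remaining chloro on the core of compound 1 gave way to hydrogen, which would set a third step beside these two on a closely related core. They also leave open whether other groups at the place of the chloro, such as fluoro, methoxy or an amine, would follow compound 3 or compound 4, and how any of these results would look across a range of concentrations.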